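This account rests on a few compounds, and the source may have more. Where it says the series, first, only, none or still open, it means among the compounds named here.

In a functional assay on the whole organism for antagonist activity, with Mus musculus as the target (a lower number here means that less compound is needed, a higher number that more compound is needed for the effect), compound 3 `CSc1nnc(-c2ccc(Cl)cc2)n1C` gives 28.1 mg/kg and compound 1 `CSc1nnc(-c2ccc(F)cc2)n1C` gives 33.4 mg/kg. The change fluoro in place of chloro on an aromatic carbon made the step of a 1.2-fold higher number from compound 3 to compound 1 (0.08 log units; within the scatter). Compound 2 `CSc1nnc(-c2ccccc2Cl)n1C` returns only a limit in this assay, > 50 mg/kg, and the reading the limit of > 50 mg/kg in this assay, at which 1 of the 3 values shown sits, is a limit, not a number. How the core of compound 2 differs from that of compound 3 is not broken down here. Compound 4 `CSc1nnc(-c2ccccc2F)n1C` is not yet measured; it arises from compound 2 by fluoro in place of chloro on an aromatic carbon, the same kind of change as before, but the place differs: in compound 2 the group sits ortho to a group of 8 heavy atoms, whereas in compound 3 it sits para to a group of 8 heavy atoms. Because the earlier step of a 1.2-fold higher number from compound 3 to compound 1 (0.08 log units; within the scatter) was small, a step that the limit leaves unreadable from compound 2 to compound 4 is expected. Compound 4 is estimated at 60 mg/kg, likely between 30 mg/kg and 150 mg/kg.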

Compound 4, dose for half-maximal effect: 8.8 mg/kg
Compound 4: the middle estimate sits 6.8-fold (0.83 log units) above what was measured; the measured number lies below the stated range.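

In this assay, fluoro in place of chloro on an aromatic carbon, ortho to a group of 8 heavy atoms, gave an at least 5.6-fold lower number from compound 2 to compound 4 (0.75 log units; beyond the scatter). Set beside the earlier step, the same change did not carry over in size from one core to the other: the same change on two cores in this assay, a 1.2-fold higher number (0.08 log units; within the scatter) from compound 3 to compound 1 and an at least 5.6-fold lower number (0.75 log units; beyond the scatter) from compound 2 to compound 4, at least 6.7-fold (0.82 log units) apart, beyond the scatter of two such steps Compound 2 gives a limit and not a number, so the true size of its step stays unknown, and two pairs do not show why the cores part: the limit of > 50 mg/kg in this assay, at which 1 of the 4 values shown sits.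

The compounds shown leave open how bromo, methoxy or a nitrile would read in this assay at that same place. They also leave open whether a longer chain on the sulfur would change the step.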